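Compound 1 and the Turn to a 2-Bromophenyl Group

The compounds below may be only part of what the source reports. "The series", "measured", "known", "first", "only" and "open" are said of these compounds alone.

Compound 1 `COc1cc(OC)c(-c2coc3cc(OCC=C(C)C)ccc3c2=O)cc1OC` is the anchor of this small set. In a functional assay on HepG2 cells (Homo sapiens) for antiproliferative activity, read by MTT assay, with a stated time of 24 h (a higher number here means a weaker inhibitor, a lower number a stronger inhibitor), compound 1 gives 280 nM, the lowest of the two numbers shown; its nearest neighbour is compound 3 `COc1cc(OC)c(-c2coc3cc(OCc4ccccc4Cl)ccc3c2=O)cc1OC`, which gives 1690 nM. Compound 2 `COc1cc(OC)c(-c2coc3cc(OCc4ccccc4C#N)ccc3c2=O)cc1OC` does not yield a number in this assay but only a limit, > 10000 nM. One of the three values shown therefore sits at the limit of > 10000 nM in this assay, at which 1 of the 3 values shown sits.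

Compound 4 `COc1cc(OC)c(-c2coc3cc(OCc4ccccc4Br)ccc3c2=O)cc1OC` has not yet been tested in this assay. Set against compound 1, the change is 2-bromophenyl in place of 2-methylprop-1-en-1-yl on a saturated chain carbon bound to an oxygen on an aromatic ring. Two measured steps start from the same point and bear on it: a 6.0-fold higher number from compound 1 to compound 3 (0.78 log units; beyond the scatter), and an at least 35-fold higher number from compound 1 to compound 2 (1.55 log units; beyond the scatter). Within the aromatic pair, an at least 5.9-fold lower number from compound 2 to compound 3 (0.77 log units; beyond the scatter). Compound 4 carries a halogen on its ring, as compound 3 does, rather than the nitrile of compound 2, so the account leans on the step to compound 3 and expects an upward movement beyond the scatter, of modest rather than large size. Compound 4 is thus expected to be a weaker inhibitor than compound 1, the estimated step being a 7.1-fold higher number from compound 1 to compound 4 (0.85 log units; beyond the scatter). In this assay compound 4 is estimated at 2000 nM, with a range from 700 nM to 6000 nM.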

Compound 4, half-maximal inhibitory concentration: 2180 nM
Compound 4: the middle estimate sits 1.1-fold (0.04 log units) below what was measured, and the stated range covers the measured number.
By their numbers in this assay, from the lowest: compound 1; then compounds 3 and 4 (each within the scatter of the next). At a limit, above all of these: compound 2.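

In this assay, a 7.8-fold higher number from compound 1 to compound 4 (0.89 log units; beyond the scatter), so a second halogen-bearing group at this place, on a saturated chain carbon bound to an oxygen on an aromatic ring, also reads modestly weaker than the 3-methylbut-2-en-1-yl group, and that rise is not confined to the chlorine of compound 3. Going by these compounds alone, the new compound also shows for the first time what changing the halogen itself does: a 1.3-fold higher number from compound 3 to compound 4 (0.11 log units; within the scatter), so bromo in place of chloro gives no change that can be told apart here. The two halogens thus read alike and stand clear of the nitrile, with an at least 4.5-fold lower number from compound 2 to compound 4 (0.66 log units; beyond the scatter), though that step rests on a limit and not on a number: the limit of > 10000 nM in this assay, at which 1 of the 4 values shown sits.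

The compounds shown leave open whether a plain benzyl group, with no halogen or nitrile on its ring, would stand with compound 1 or with compounds 3 and 4. They also leave open how a fluoro or methoxy group on that aromatic carbon, or a longer chain such as geranyl in place of 3-methylbut-2-en-1-yl, would read in this assay.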